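Swapping Methyl for Methoxy on the Anilide Ring

The source may hold more compounds than are shown below. What is called first, only, known or untested is meant among the compounds shown, and "the series" means these compounds.

Measured compounds:
- compound 1, `O=C(O)CCC(=O)OCCCCCCSc1ccc([N+](=O)[O-])c2nonc12`, gives 3640 nM in a functional assay on A549 cells (Homo sapiens) for inhibition, read by MTT assay, with a stated time of 72 h; on this read-out higher numbers stand for weaker inhibition and lower numbers for stronger inhibition.
- compound 2, `Cc1ccccc1NC(=O)CCC(=O)OCCCCCCSc1ccc([N+](=O)[O-])c2nonc12`, gives 4200 nM in this assay.

Compound 2 holds the higher of the two numbers, but the step of a 1.2-fold higher number from compound 1 to compound 2 (0.06 log units; within the scatter) is within the scatter, so the two compounds cannot be told apart on these data. That step replaced a hydroxy on the carbonyl carbon with a (2-methylphenyl)amino group, a sizeable change at the tail that left the read-out essentially unchanged.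

Compound 3, `COc1ccccc1NC(=O)CCC(=O)OCCCCCCSc1ccc([N+](=O)[O-])c2nonc12`, carries the difference methoxy in place of methyl on an aromatic carbon relative to compound 2. Within the data shown here, no measured pair shows this particular swap, so the only guide is the single step of a 1.2-fold higher number from compound 1 to compound 2 (0.06 log units; within the scatter), which suggests that edits at this end of the molecule do not move the number much. A further small edit, methoxy in place of methyl on an aromatic carbon, is therefore expected to give no step beyond the scatter in this assay.

Compound 3 is estimated at 4200 nM, with a range of 2000 nM to 9000 nM, an expected step of no change at the digits printed from compound 2 to compound 3 (within the scatter).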

Compound 3, half-maximal inhibitory concentration: 1870 nM
For compound 3 the middle estimate is 2.2-fold (0.35 log units) above the measured one; measured number outside the range, below it.
By their numbers in this assay, from the lowest: compounds 3, 1 and 2 (each within the scatter of the next, the first and the last beyond it).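

The earlier pair hinted that this end of the molecule hardly matters in this assay, but this swap on an aromatic carbon, ortho to a large group, gives a 2.2-fold lower number from compound 2 to compound 3 (0.35 log units; beyond the scatter). That is a modest step, yet it lies beyond the scatter, so this one place on the ring can shift the read-out even though replacing the hydroxy with the whole (2-methylphenyl)amino group did not. The step from the acid tells a more restrained story, with a 1.9-fold lower number from compound 1 to compound 3 (0.29 log units; within the scatter) lying within the scatter, so compound 3 can be separated from compound 2 but not from compound 1, and nothing available here explains why methoxy and methyl differ.

The compounds shown leave open whether the step depends on the oxygen of the methoxy group, since ethoxy, chlorine or a plain hydrogen on this same carbon would each help to test that. Going by these compounds, it also remains open whether the difference between compound 2 and compound 3 would persist with a shorter or longer chain in place of the hexyl linker.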